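The compounds below may be only part of what the source reports. "The series", "measured", "known", "first", "only" and "open" are said of these compounds alone.

Series notes. In a functional assay on the whole organism (blood, strain Charles Foster/Wistar albino) with Rattus norvegicus as the target, with a stated time of 30 min, at a dose of 100 mg/kg by the oral route (on this read-out higher numbers stand for more inhibition at the one dose given (going by the name of the read-out) and lower numbers for less inhibition), compound 1 `CCN(CC)CCCOc1cc(OC)ccc1-c1cc(-c2ccccc2)no1` gives 14.3%, compound 2 `COc1ccc(-c2cc(-c3ccccc3)no2)c(OCCCN2CCCCC2)c1` gives 20.8%, and compound 3 `COc1ccc(-c2cc(-c3ccccc3)no2)c(OCC(O)CN2CCCCC2)c1` gives 17%. On the numbers as they read, compound 3 sits second of the three, yet it lies within the scatter of both neighbours: a number 2.7 percentage points higher from compound 1 to compound 3 (within the scatter) and a number 3.8 percentage points lower from compound 2 to compound 3 (within the scatter). Compound 4 `COc1ccc(-c2cc(-c3ccccc3)no2)c(OCCCN2CCCC2)c1` has not yet been run in this assay. Change from compound 3 to compound 4: 2-(pyrrolidin-1-yl)ethyl in place of 1-hydroxy-2-(piperidin-1-yl)ethyl on a saturated chain carbon bound to an oxygen on an aromatic ring. Going by the values given here, two measured steps bear on it, a number 6.5 percentage points higher from compound 1 to compound 2 (within the scatter) and a number 3.8 percentage points lower from compound 2 to compound 3 (within the scatter), and both stayed within the scatter; a five-membered ring in place of a six-membered one has no measured step of its own. No step beyond the scatter is therefore expected, a number 1 percentage points higher from compound 3 to compound 4 (within the scatter). Compound 4 is expected at 18%, with a range from 8% to 30%.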

Compound 4, a percentage reported as inhibition, in the whole organism at one dose (the size of the read-out at that dose, not a potency): 21.2%
Compound 4: middle estimate off by 3.2 percentage points, on the low side; low and high end bracket the measured number.
By their numbers in this assay, from the lowest: compounds 1, 3, 2 and 4 (each within the scatter of the next).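

In this assay, the five-membered ring gets its first reading: a number 0.4 percentage points higher from compound 2 to compound 4 (within the scatter) for pyrrolidin-1-yl in place of piperidin-1-yl on the same chain. The wider changes at this position, a number 4.2 percentage points higher from compound 3 to compound 4 (within the scatter) and a number 6.9 percentage points higher from compound 1 to compound 4 (within the scatter), also leave the read-out inside the scatter, so no group tried here separates from another. No measurement bears on the reason for these steps. Open, going by these compounds, is whether a morpholin-4-yl group or a shorter chain would step beyond the scatter, and how 2-hydroxy-3-(pyrrolidin-1-yl)propyl would read.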